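The source may report more compounds than this note shows. Statements on the series, on what has been measured and on what is new or still open speak of the compounds shown alone.

Measured so far:
- compound 1, `Brc1ccccc1COc1nc2ccccc2s1`: 75.6%
- compound 2, `c1ccc(OCCOc2nc3ccccc3s2)cc1`: 7.31%

In a functional assay on the whole organism with Mus musculus as the target, with a stated time of 1 h, at a dose of 100 mg/kg by the intraperitoneal route (on this read-out lower numbers stand for less inhibition and higher numbers for more inhibition at the one dose given (going by the name of the read-out)), compound 1 gives 75.6%, the higher of the two numbers in hand. Compound 2 gives 7.31% in this assay, a gap that lies beyond the usual scatter. Compound 3, `FC(F)(F)c1ccccc1COc1nc2ccccc2s1`, has not yet been measured in this assay. It differs from compound 1 by trifluoromethyl in place of bromo on an aromatic carbon. Among the measured compounds shown here, with no matched pair of this kind among the measured compounds, the expected step from compound 1 to compound 3, a number 13.6 percentage points lower from compound 1 to compound 3 (beyond the scatter), is small and downward, likely within the scatter. Compound 3 is expected to give 62%, with a range of 30% to 85%.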

Compound 3, a percentage reported as inhibition, in the whole organism at one dose (the size of the read-out at that dose, not a potency): 9.75%
Compound 3: the middle estimate sits 52.3 percentage points above what was measured; measured number outside the range, below it.
By their numbers in this assay, from the lowest: compounds 2 and 3 (each within the scatter of the next); then compound 1.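

In this assay, among the compounds shown here, trifluoromethyl in place of bromo on an aromatic carbon, ortho to a large group, gives a number 65.9 percentage points lower from compound 1 to compound 3 (beyond the scatter) and is the first single-place step. The read-out at this one dose is therefore sensitive to which group sits at this position, and the inhibition seen with compound 1 does not carry over to trifluoromethyl. Nothing at hand explains this step. Still open, from the compounds shown here alone, is whether the inhibition is particular to bromo or is shared by chloro, iodo, methoxy or an amine on the same carbon. A single dose also leaves potency open.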